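The compounds below may be only part of what the source reports. "The series", "measured", "known", "first", "only" and "open" are said of these compounds alone.

Compound 2, `N#CC1=C(N)Oc2c(N)cc3nc4ccccc4nc3c2C12C(=O)N(Cc1cnnn1-c1ccc(Cl)cc1)c1ccccc12`, carries a chloro group and was tested in a functional assay on HCT-116 cells (Homo sapiens) for antiproliferative activity, read by MTT assay, with a stated time of 48 h; on this read-out lower numbers stand for stronger inhibition and higher numbers for weaker inhibition. In this assay compound 2 gives > 50000 nM, which is a limit of the assay and not a number. Its companion, compound 1, `N#CC1=C(N)Oc2c(c3nc4ccccc4nc3c3ccccc23)C12C(=O)N(Cc1cnnn1-c1ccc(Br)cc1)c1ccccc12`, is likewise known only to a limit. In this assay compound 1 gives > 50000 nM, again a limit rather than a number. Both compounds thus rest at the same ceiling, as summarised by the limit of > 50000 nM in this assay, at which 2 of the 2 values shown sit, so compound 2 cannot be placed above or below compound 1 on what has been measured. Compound 3, `N#CC1=C(N)Oc2c(N)cc3nc4ccccc4nc3c2C12C(=O)N(Cc1cnnn1-c1ccc([N+](=O)[O-])cc1)c1ccccc12`, differs from compound 2 in one place, (nitro in place of chloro on an aromatic carbon). Among the compounds with values here, with no measured step between compounds to lean on, the author expects the change to leave potency essentially unchanged, a step that the limit leaves unreadable from compound 2 to compound 3, that is, no shift beyond the usual scatter. Compound 3 is estimated at 60000 nM, with a range from 15000 nM to 200000 nM.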

Compound 3, half-maximal inhibitory concentration: > 50000 nM
Compound 3: a limit, no number; the forecaster's own chance of this, stated with the estimate: 75%; the middle value does not contradict the limit.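

Compound 3 also turns out to be only a limit and not a number, so no step can be read from compound 2 to compound 3: the limit of > 50000 nM in this assay, at which 3 of the 3 values shown sit. The compounds shown leave open how nitro and chloro compare in this assay, and whether any of the three compounds differs from the others.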